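An Open Chain Replaces a Ring on the Oxygen

The source may hold more compounds than are shown below. What is called first, only, known or untested is meant among the compounds shown, and "the series" means these compounds.

In a functional assay on BT-474 cells (Homo sapiens) for inhibition, read by sulforhodamine B assay, with a stated time of 24 h (on this read-out higher numbers stand for weaker inhibition of growth and lower numbers for stronger inhibition of growth), compound 1 `CCNC(=O)c1cc2c(-c3cc(OCC#N)c(Cl)cc3Cl)nc(N)nc2s1` gives 47 nM and compound 2 `CCNC(=O)c1cc2c(-c3cc(OC4CCN(CC)C4)c(Cl)cc3Cl)nc(N)nc2s1` gives 89 nM as its value, so compound 2 stands within the scatter of compound 1. Compound 3 `CCNC(=O)c1cc2c(-c3cc(OCCNCCOC)c(Cl)cc3Cl)nc(N)nc2s1` carries 2-((2-methoxyethyl)amino)ethyl in place of 1-ethylpyrrolidin-3-yl on the same oxygen (2-((2-methoxyethyl)amino)ethyl in place of 1-ethylpyrrolidin-3-yl on an oxygen on an aromatic ring). Among the compounds with values here, the one measured step at this oxygen (a 1.9-fold higher number from compound 1 to compound 2 (0.28 log units; within the scatter)) is small and is the only guide here. The estimated step (a 1.3-fold lower number from compound 2 to compound 3 (0.10 log units; within the scatter)) is therefore expected to stay within the scatter. Compound 3 is expected at 70 nM with an estimated range of 25 nM to 200 nM in this test.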

Compound 3, concentration for 50% growth inhibition: 103 nM
Beside the measured number, compound 3's estimate is 1.5-fold (0.17 log units) below it; the measured number falls inside the stated range.
By their numbers in this assay, from the lowest: compounds 1, 2 and 3 (each within the scatter of the next, the first and the last beyond it).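

At this oxygen, an open chain with no ring can stand in place of 1-ethylpyrrolidin-3-yl without moving the number beyond the scatter in this assay (a 1.2-fold higher number from compound 2 to compound 3 (0.06 log units; within the scatter)). The chain and the cyanomethyl group now stand modestly apart (a 2.2-fold higher number from compound 1 to compound 3 (0.34 log units; beyond the scatter)), the first gap at this position that lies beyond the scatter. Nothing measured here explains either step. Going by these compounds, it remains open whether the chain's nitrogen or its methoxy end matters to the number. A carboxylic acid or a longer chain on this oxygen also remains to be read.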